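This account rests on a few compounds, and the source may have more. Where it says the series, first, only, none or still open, it means among the compounds named here.

Working notes on the sulfonamide series. In an ADME assay for permeability, using PAMPA, with a stated time of 4 h, at pH 7.4, tested at 5 uM (a higher number here means that the compound crosses the layer faster, a lower number that the compound crosses the layer more slowly), compound 2 (`Cn1nccc1[C@H]1CCC[C@@H]1Oc1cc(F)c(S(=O)(=O)Nc2nccs2)cc1F`) gives > 50 10^-6 cm/s, which is a limit of the assay and not a number. Compound 2 therefore stands at the limit of > 50 10^-6 cm/s in this assay, at which 1 of the 2 values shown sits. Compound 1 (`Cn1nccc1[C@H]1CCCC[C@@H]1Oc1cc(F)c(S(=O)(=O)Nc2ccncn2)c(F)c1`) gives a numeric reading of 2.2 10^-6 cm/s in this assay. For the measured compounds named here, no two measured compounds differ in one place only, so no measured step is available for sizing the next change.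

Compound 3 (`Cn1nccc1[C@H]1CCC[C@@H]1Oc1cc(F)c(S(=O)(=O)Nc2ncns2)cc1F`) carries 1,2,4-thiadiazol-5-yl in place of 1,3-thiazol-2-yl on a sulfonamide nitrogen. The rest of the structure stays as in compound 2.

The expectation for this assay starts from compound 2, whose > 50 10^-6 cm/s is a limit, so its size is loosely held. A moderate drop beyond the scatter is expected, with the estimated step being an at least 2.5-fold lower number from compound 2 to compound 3 (0.39 log units; beyond the scatter). A reading at the same limit remains possible. For compound 3 the estimate is 20 10^-6 cm/s, with the measurement expected to fall between 6 10^-6 cm/s and 60 10^-6 cm/s.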

Compound 3, apparent permeability: 0.3 10^-6 cm/s
The estimate for compound 3 lay 67-fold (1.82 log units) above the measured number; measured number outside the range, below it.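

Compound 3 gives the series its first measured step at this position: in this assay, with the rest of the structure unchanged, 1,2,4-thiadiazol-5-yl in place of 1,3-thiazol-2-yl on a sulfonamide nitrogen gives an at least 160-fold lower number from compound 2 to compound 3 (2.22 log units; beyond the scatter). Both groups have 5 heavy atoms and form one five-membered aromatic ring, so a large step here comes with a change from 2 to 3 hetero atoms in the ring and no change in heavy-atom count. The reading for compound 2 is a limit of the assay and not a number, so the step has a floor but no upper bound: the limit of > 50 10^-6 cm/s in this assay, at which 1 of the 3 values shown sits.

The compounds shown do not tell what in the exchange accounts for the step, nor whether it would be of similar size on the core of compound 1, which differs from compound 2 in more than one place. Also open, as far as these compounds go, is how the reading would respond to other rings on the sulfonamide nitrogen, such as an oxazol-2-yl or a pyridin-2-yl group.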